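Aryl-alkynyl series: bromo to methyl on the ring

A few compounds are considered here, and "the series" means these few. Any claim that something is new, unique, unknown or untested is made for them only; others in the source may bear on it.

Compound 2 `O=C1c2ccccc2C(=O)N1C/C=C\Cn1cc(C#Cc2ccc(Br)cc2)c(=O)[nH]c1=O` stands at the weak end of this small set: in a functional assay on MOLT-4 cells (Homo sapiens) for antiproliferative activity, read by MTT assay, with a stated time of 3 days (a lower number here means a stronger inhibitor, a higher number a weaker inhibitor), compound 2 gives 89000 nM, the highest of the three measured numbers, and its gaps to both other compounds lie beyond the scatter. Compound 3 `O=C1c2ccccc2C(=O)N1C/C=C/Cn1cc(C#CCCc2ccccc2)c(=O)[nH]c1=O` gives 39000 nM, and compound 1 `CCCCCCC#Cc1cn(C/C=C/CN2C(=O)c3ccccc3C2=O)c(=O)[nH]c1=O` gives 35000 nM. Going by the values given here, the single step that differs in one place, a 1.1-fold higher number from compound 1 to compound 3 (0.05 log units; within the scatter), concerns the far end of the alkyne substituent and stays within the scatter; it does not involve the aromatic ring.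

The step followed here runs from compound 2 to compound 4 `Cc1ccc(C#Cc2cn(C/C=C\CN3C(=O)c4ccccc4C3=O)c(=O)[nH]c2=O)cc1`: methyl in place of bromo on an aromatic carbon. Among the compounds with values here, no measured pair in the set shows a methyl in place of a bromo, so there is nothing to transfer directly. Compound 2 and compound 3 differ in more than one place, so their gap cannot be read as a single change. Within the data shown here, with the only measured step within the scatter and no precedent for the substitution on the aromatic carbon, the step expected from compound 2 to compound 4 is a 1.3-fold lower number from compound 2 to compound 4 (0.10 log units; within the scatter), that is, nothing beyond the scatter. Compound 4 is therefore estimated at 70000 nM in this assay, with a range from 30000 nM to 180000 nM.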

Compound 4, half-maximal inhibitory concentration: 266000 nM
The estimate for compound 4 lay 3.8-fold (0.58 log units) below the measured number; the whole stated range lies below it.
By their numbers in this assay, from the lowest: compounds 1 and 3 (each within the scatter of the next); then compound 2; then compound 4.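

In this assay, the ring carbon para to a large group responds to a small exchange: a 3.0-fold higher number from compound 2 to compound 4 (0.48 log units; beyond the scatter), with methyl in place of bromo. Going by these compounds alone, the one earlier single-place step, a 1.1-fold higher number from compound 1 to compound 3 (0.05 log units; within the scatter), changed the far end of the alkyne substituent and stayed within the scatter, whereas this step on a ring substituent lies beyond it, even though one heavy atom replaces one heavy atom and the counts of rings, hydrogen-bond donors, hydrogen-bond acceptors and net charge stay the same. Nothing available bears on why the number rises with this exchange.

As far as these compounds go, with only 4-bromophenyl and 4-methylphenyl to compare, it remains open whether bromo favours the activity or methyl disfavours it, and an unsubstituted phenyl or a ring carrying chloro, methoxy or a nitrile at this carbon would help to settle that. From the compounds shown here alone, it is also open whether the same exchange gives a step of similar size on the other alkene geometry, that of compound 1 and compound 3, where an aryl-alkynyl pair would be needed to test it.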